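Shifting the aryl substituent on the N-oxy ring: sulfonyl for ester

The source may report more compounds than this note shows. Statements on the series, on what has been measured and on what is new or still open speak of the compounds shown alone.

Measured compounds:
- compound 1 `CCOCCON1C(=O)[C@@H](NC(=O)OCCCCC2CCCCC2)[C@@H]1C`: 187 nM
- compound 2 `C[C@H]1[C@H](NC(=O)OCCCCC2CCCCC2)C(=O)N1OCCCS(C)(=O)=O`: 49 nM
- compound 3 `COC(=O)c1ccc(ON2C(=O)[C@@H](NC(=O)OCCCCC3CCCCC3)[C@@H]2C)cc1`: 17 nM

In an assay on HEK293 cells for inhibition of N-acylethanolamine-hydrolyzing acid amidase (Homo sapiens), read by fluorescence, with stated times of 10 min and 50 min (on this read-out higher numbers stand for weaker inhibition and lower numbers for stronger inhibition), compound 3 holds the lowest number of the three, beyond the scatter from both others. The unmeasured compound 4 `C[C@H]1[C@H](NC(=O)OCCCCC2CCCCC2)C(=O)N1Oc1ccccc1S(C)(=O)=O` differs from compound 3 by 2-(methylsulfonyl)phenyl in place of 4-(methoxycarbonyl)phenyl on an oxygen. Within the data shown here, no measured step swaps one aryl substituent for another. The closest guides are a 3.8-fold lower number from compound 1 to compound 2 (0.58 log units; beyond the scatter), where a methylsulfonyl group arrived on a chain, and a 2.9-fold lower number from compound 2 to compound 3 (0.46 log units; beyond the scatter), where an aryl group replaced that chain. Since compound 4 keeps the aryl group and gains a methylsulfonyl, only a small shift in this assay is expected, in either direction. Compound 4 is therefore estimated at 25 nM, between 8 nM and 80 nM, a step of a 1.5-fold higher number from compound 3 to compound 4 (0.17 log units; within the scatter).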

Compound 4, half-maximal inhibitory concentration: 6 nM
The estimate for compound 4 lay 4.2-fold (0.62 log units) above the measured number; measured number outside the range, below it.
By their numbers in this assay, from the lowest: compound 4; then compound 3; then compound 2; then compound 1.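

In this assay, swapping one aryl group for another on this oxygen still shifts the number (a 2.8-fold lower number from compound 3 to compound 4 (0.45 log units; beyond the scatter)), so the aryl groups here are not interchangeable. Against the chains, 2-(methylsulfonyl)phenyl goes further (an 8.2-fold lower number from compound 2 to compound 4 (0.91 log units; beyond the scatter); a 31-fold lower number from compound 1 to compound 4 (1.49 log units; beyond the scatter)), leaving compound 4 with the lowest number of the four. No measurement shown explains this shift.

Open, going by these compounds, is whether the sulfonyl group or its place on the ring drives the result. A 4-(methylsulfonyl)phenyl or 2-(methoxycarbonyl)phenyl group would separate the two.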